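From Carboxy to Carbamoyl: Testing Compound 4

The compounds below may be only part of what the source reports. "The series", "measured", "known", "first", "only" and "open" are said of these compounds alone.

Compound 1 `Cc1ccc(OCC(=O)Nc2cccc(C(=O)O)c2)cc1` is the starting point, tested in a functional assay on AGS cells (Homo sapiens) for inhibition, read by reporter gene assay; on this read-out higher numbers stand for weaker inhibition and lower numbers for stronger inhibition. Compound 1 reads > 30000 nM, which is a limit of the assay and not a number, and so it stands at the limit of > 30000 nM in this assay, at which 2 of the 3 values shown sit. Compound 2 `CC(=O)c1ccc(OCC(=O)Nc2cccc(C(=O)O)c2)cc1`, with acetyl in place of methyl on an aromatic carbon, reads > 30000 nM, which is also a limit. This leaves a step that the two limits leave unreadable from compound 1 to compound 2. Going by the values given here, compound 3 `O=C(COc1ccc(I)cc1)Nc1cccc(C(=O)O)c1`, with iodo at that same place, gives 3500 nM, the only true number so far. That makes an at least 8.5-fold lower number from compound 1 to compound 3 (0.93 log units; beyond the scatter), and also an at least 8.5-fold lower number from compound 2 to compound 3 (0.93 log units; beyond the scatter).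

Compound 4 `Cc1ccc(OCC(=O)Nc2cccc(C(N)=O)c2)cc1` keeps the methyl and changes a different part of the molecule: amino in place of hydroxy on a carbonyl carbon. This is amino in place of hydroxy on a carbonyl carbon, or carboxy to carbamoyl. Among the compounds with values here, none of the measured steps touches this place, so they give no direct size for the change. Among the measured compounds, only compound 3 at 3500 nM gives a readable number, and compound 4 has methyl rather than iodo. No gain beyond the scatter is therefore expected, and the expected outcome is a number no higher from compound 1 to compound 4 (the limit leaves the size open). Compound 4 is estimated at 30000 nM, with an expected range of 12000 nM to 60000 nM, and it may well return only a limit.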

Compound 4, half-maximal inhibitory concentration: > 30000 nM
Compound 4 gave a limit, no number; the forecaster's own chance of this, stated with the estimate: 85%; the middle value lies on the limit itself.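

In this assay compound 4 gives > 30000 nM, which is a limit and not a number. Compound 1 also sits at a limit, so no new step can be read between compound 1 and compound 4: the limit of > 30000 nM in this assay, at which 3 of the 4 values shown sit.

The compounds shown leave open how large the change from carboxy to carbamoyl is, or whether it changes the number at all.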